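Removing one fluorine from the difluorophenyl ring of compound 3

A few compounds are considered here, and "the series" means these few. Any claim that something is new, unique, unknown or untested is made for them only; others in the source may bear on it.

Three close relatives of a shared core have been tested in a functional assay on HT-29 cells (Homo sapiens) for inhibition, read by MTT assay; on this read-out higher numbers stand for weaker inhibition and lower numbers for stronger inhibition. Compound 1 `COc1cc2c(Oc3ccc(NC(=O)NN4C(=O)CSC4c4ccc(F)cc4)cc3)ccnc2cc1OC1CCN(C(=O)NC(C)C)CC1` gives 860 nM, compound 2 `COc1cc2c(Oc3ccc(NC(=O)NN4C(=O)CSC4c4ccccc4)cc3)ccnc2cc1OC1CCN(C(=O)NC(C)C)CC1` gives 1260 nM, and compound 3 `COc1cc2c(Oc3ccc(NC(=O)NN4C(=O)CSC4c4cccc(F)c4F)cc3)ccnc2cc1OC1CCN(C(=O)NC(C)C)CC1` gives 790 nM, the lowest of the three numbers, though all three lie within the usual scatter of one another. Compound 4 `COc1cc2c(Oc3ccc(NC(=O)NN4C(=O)CSC4c4ccccc4F)cc3)ccnc2cc1OC1CCN(C(=O)NC(C)C)CC1` differs from compound 3 by hydrogen in place of fluoro on an aromatic carbon. Among the compounds with values here, the closest precedent is a 1.5-fold higher number from compound 1 to compound 2 (0.17 log units; within the scatter), also a fluoro-to-hydrogen swap on the same ring; a 1.6-fold lower number from compound 2 to compound 3 (0.20 log units; within the scatter) and a 1.1-fold lower number from compound 1 to compound 3 (0.04 log units; within the scatter) were likewise within the scatter. No step beyond the scatter is therefore expected in this assay, and compound 4 is estimated at 950 nM, between 450 nM and 2000 nM, a step of a 1.2-fold higher number from compound 3 to compound 4 (0.08 log units; within the scatter).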

Compound 4, half-maximal inhibitory concentration: 410 nM
Compound 4: the middle estimate sits 2.3-fold (0.36 log units) above what was measured; the measured number lies below the stated range.
By their numbers in this assay, from the lowest: compounds 4, 3, 1 and 2 (each within the scatter of the next, the first and the last beyond it).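

In this assay, swapping fluoro for hydrogen does not have one fixed effect across these phenyl rings: the same change on two cores in this assay, a 1.5-fold higher number (0.17 log units; within the scatter) from compound 1 to compound 2 and a 1.9-fold lower number (0.28 log units; within the scatter) from compound 3 to compound 4, 2.8-fold (0.45 log units) apart, beyond the scatter of two such steps. Although a 1.9-fold lower number from compound 3 to compound 4 (0.28 log units; within the scatter), 2-fluorophenyl stands apart from phenyl, with a 3.1-fold lower number from compound 2 to compound 4 (0.49 log units; beyond the scatter), and from 4-fluorophenyl, with a 2.1-fold lower number from compound 1 to compound 4 (0.32 log units; beyond the scatter). Among these rings, then, the place of a single fluoro group matters as well as its presence. Going by these compounds, whether a chloro or methoxy group in place of that fluoro group would give a similar number remains open.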